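Swapping the aryl group on a cyclopentane urea

This account rests on a few compounds, and the source may have more. Where it says the series, first, only, none or still open, it means among the compounds named here.

Three ureas sharing one core have been measured in an assay on microsomes for inhibition of acyl-CoA:cholesterol acyltransferase (Oryctolagus cuniculus); on this read-out higher numbers stand for weaker inhibition and lower numbers for stronger inhibition. Compound 1 `Cc1ccc(C2(CNC(=O)Nc3c(C(C)C)cccc3C(C)C)CCCC2)cc1` gives 25 nM. Compound 2 `CC(C)c1cccc(C(C)C)c1NC(=O)NCC1(c2ccc(Cl)cc2)CCCC1` gives 32 nM. Compound 3 `CC(C)c1cccc(C(C)C)c1NC(=O)NCC1(c2ccccc2C(F)(F)F)CCCC1` gives 18 nM, the smallest of the three numbers, yet the steps of a 1.4-fold lower number from compound 1 to compound 3 (0.14 log units; within the scatter) and a 1.8-fold lower number from compound 2 to compound 3 (0.25 log units; within the scatter) both stay within the scatter, so no real separation between these three compounds is established.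

Compound 4 `CC(C)c1cccc(C(C)C)c1NC(=O)NCC1(c2cccc(N(C)C)c2)CCCC1` differs from compound 3 in one place: 3-(dimethylamino)phenyl in place of 2-(trifluoromethyl)phenyl on a saturated ring carbon. The two earlier changes at this same saturated ring carbon, a 1.4-fold lower number from compound 1 to compound 3 (0.14 log units; within the scatter) and a 1.8-fold lower number from compound 2 to compound 3 (0.25 log units; within the scatter), along with the change on the aromatic carbon, a 1.3-fold higher number from compound 1 to compound 2 (0.11 log units; within the scatter), all stayed within the scatter, so this part of the molecule has so far tolerated different aryl groups without a clear shift in this assay. For the measured compounds named here, no step with a dimethylamino group exists among the measured compounds, so any expectation rests on that tolerance alone.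

Compound 4 is therefore expected to give about 28 nM in this assay, with a range from 10 nM to 80 nM. The expected step is a 1.6-fold higher number from compound 3 to compound 4 (0.19 log units; within the scatter), which is no change beyond the scatter.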

Compound 4, half-maximal inhibitory concentration: 33 nM
Estimate against measurement, compound 4: 1.2-fold (0.07 log units) below; measured number inside the range.
By their numbers in this assay, from the lowest: compounds 3, 1, 2 and 4 (each within the scatter of the next).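

For the compounds shown here, the 3-(dimethylamino)phenyl group is the first aryl group in this set to carry a nitrogen and a hydrogen-bond acceptor, yet in this assay every comparison stays within the scatter (a 1.8-fold higher number from compound 3 to compound 4 (0.26 log units; within the scatter); a 1.0-fold higher number from compound 2 to compound 4 (0.01 log units; within the scatter); a 1.3-fold higher number from compound 1 to compound 4 (0.12 log units; within the scatter)). The tolerance seen at this saturated ring carbon therefore now reaches beyond aryl groups bearing methyl, chloro or trifluoromethyl to one bearing a dimethylamino group. Nothing measured here explains why these numbers stay so close.

On these data alone, all four compounds keep an aryl group on this carbon, so it remains open whether a carboxylic acid on that aryl group, or a plain butyl chain in its place, would stay as close. Also open, as far as these compounds go, is whether changes elsewhere in the shared core would be tolerated as well.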